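Swapping a fused heteroaromatic ketone for a plain phenyl ketone

The source may report more compounds than this note shows. Statements on the series, on what has been measured and on what is new or still open speak of the compounds shown alone.

Among the measured compounds shown here, compound 1 `CCCCCCCC/C=C\CCCCCCC(=O)c1nc2cnccc2o1` holds the lowest number so far in an assay on isolated protein for inhibition of Fatty-acid amide hydrolase 1 (Homo sapiens) (a lower number here means a stronger inhibitor, a higher number a weaker inhibitor), giving 7.2 nM. Its nearest neighbour is compound 3 `O=C(CCCCSCc1ccccc1)c1ncc(-c2ccccn2)o1`, which in this assay gives 25 nM, a gap beyond the scatter. Compound 2 `CCCCCCCC/C=C\CCCCCCC(=O)c1nc(-c2ccccc2)c(-c2ccccc2)o1` reaches only a limit of the assay, > 100000 nM (the limit of > 100000 nM in this assay, at which 1 of the 3 values shown sits). Compound 4 `CCCCCCCC/C=C\CCCCCCC(=O)c1ccccc1` has not been measured; it differs from compound 1 by a group of 6 heavy atoms (6 carbon; one six-membered aromatic ring of carbon only) in place of a group of 9 heavy atoms (6 carbon, 2 nitrogen, 1 oxygen; one five-membered aromatic ring with 2 hetero atoms, one six-membered aromatic ring with 1 hetero atom), on a carbonyl carbon. For the measured compounds named here, no measured pair isolates this change, so the step is expected rather than known: from compound 1 to compound 4 a clearly weaker result is expected, a 690-fold higher number from compound 1 to compound 4 (2.84 log units; beyond the scatter), well beyond the scatter. Compound 4 is therefore estimated at 5000 nM, within a range from 800 nM to 40000 nM.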

Compound 4, inhibition constant: > 100000 nM
Compound 4: a limit, no number; the forecaster's own chance of this, stated with the estimate: 10%; middle value at least 20-fold (1.30 log units) from the limit.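

On this carbonyl carbon the choice of ring group matters greatly: with the chain unchanged, phenyl in place of the two-ring group of compound 1 gives an at least 13000-fold higher number from compound 1 to compound 4 (4.14 log units; beyond the scatter) in this assay. Among the compounds shown here, this is the first measured pair that isolates the change, and it shows that a ring of carbon only does not stand in for rings carrying hetero atoms. Compound 4 gives a limit, not a number: the limit of > 100000 nM in this assay, at which 2 of the 4 values shown sit.

Which of the departing hetero atoms count remains open. So does whether a single pyridyl or thiazole ring on this carbonyl carbon would restore a low number.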